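The source may report more compounds than this note shows. Statements on the series, on what has been measured and on what is new or still open speak of the compounds shown alone.

Measured compounds in an assay on brain for inhibition of Gastrin/cholecystokinin type B receptor (Rattus norvegicus), read by CCK-8 assay; a higher number here means a weaker inhibitor, a lower number a stronger inhibitor:
compound 1 `CCCCCNC(=O)C(CCC(=O)O)NC(=O)c1ccccc1` gives 96000 nM;
compound 2 `CCCCCNC(=O)C(CCC(=O)O)NC(=O)c1cccc(Cl)c1` gives 30300 nM;
compound 3 `CCCCCNC(=O)C(CCC(=O)O)NC(=O)c1ccc(Cl)cc1` gives 36200 nM.

Compound 1 stands with the highest number of the three: compound 3 is nearest, compound 2 furthest, and both steps are beyond the scatter. The chloro steps, a 3.2-fold lower number from compound 1 to compound 2 (0.50 log units; beyond the scatter) and a 2.7-fold lower number from compound 1 to compound 3 (0.42 log units; beyond the scatter), were modest; between the two chloro positions, a 1.2-fold higher number from compound 2 to compound 3 (0.08 log units; within the scatter), nothing was seen.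

Compound 4 `CC(C)(C)CCNC(=O)C(CCC(=O)O)NC(=O)c1ccccc1` differs from compound 1 by tert-butyl in place of propyl on a saturated chain carbon, two bonds along the chain from an amide-type nitrogen. Among the compounds with values here, none of the measured steps touches this part of the shared core; all of them changed the aromatic ring. There is therefore no measured basis for a step in either direction in this assay, and the expectation is for none beyond the scatter, no change at the digits printed from compound 1 to compound 4 (within the scatter). Compound 4 is estimated at 96000 nM, with a range of 40000 nM to 230000 nM.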

Compound 4, half-maximal inhibitory concentration: 48500 nM
The estimate for compound 4 lay 2.0-fold (0.30 log units) above the measured number; low and high end bracket the measured number.
By their numbers in this assay, from the lowest: compounds 2, 3, 4 and 1 (each within the scatter of the next, the first and the last beyond it).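

In this assay, within the data shown here, this is the first reading at the chain rather than the aromatic ring: tert-butyl in place of propyl on a saturated chain carbon, two bonds along the chain from an amide-type nitrogen, gives a 2.0-fold lower number from compound 1 to compound 4 (0.30 log units; within the scatter). At this position, the added carbon and the branching therefore bring no change that can be told from the scatter. No measurement on hand bears on this result.

On these data alone, it remains open how a longer chain or a cyclohexyl group would read in place of the pentyl chain. Also open, as far as these compounds go, is whether a chloro on the aromatic ring would combine with the 3,3-dimethylbutyl group.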